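Hydroxy and Methoxy Swap on the Phenyl Group

The source may report more compounds than this note shows. Statements on the series, on what has been measured and on what is new or still open speak of the compounds shown alone.

Among the measured compounds shown here, compound 2 `CN(C)CCn1cnnc1-c1cc(Oc2ccc(NC(=O)N/N=C/c3ccc(O)cc3)cc2F)ccn1` stands at the higher end of the two numbers so far obtained in a functional assay on HT-29 cells (Homo sapiens) for cytotoxicity, read by MTT assay, with a stated time of 72 h (on this read-out lower numbers stand for stronger inhibition and higher numbers for weaker inhibition), where compound 2 gives 1920 nM. Its nearest neighbour is compound 1 `CN(C)CCn1cnnc1-c1cc(Oc2ccc(NC(=O)N/N=C/c3ccc(O)c(O)c3)cc2F)ccn1`, which in this assay gives 1890 nM; the step of a 1.0-fold higher number from compound 1 to compound 2 (0.01 log units; within the scatter) lies within the scatter, so the two compounds cannot be ordered. Compound 3 `COc1ccc(/C=N/NC(=O)Nc2ccc(Oc3ccnc(-c4nncn4CCN(C)C)c3)c(F)c2)cc1O` has not yet been measured. It differs from compound 2 by 3-hydroxy-4-methoxyphenyl in place of 4-hydroxyphenyl on a carbon with a double bond to nitrogen. For the measured compounds named here, the only measured step that bears on this change is a 1.0-fold higher number from compound 1 to compound 2 (0.01 log units; within the scatter), in which a hydroxy on the same phenyl group was replaced by hydrogen without any shift beyond the scatter. Compound 3 turns the hydroxy of compound 2 into a methoxy and brings in a further hydroxy, a change of a similar modest kind on the same group, so no step beyond the scatter is expected in this assay from compound 2 to compound 3. Compound 3 is therefore expected to give about 1900 nM, with a range of 900 nM to 4000 nM, which would mean an expected step of a 1.0-fold lower number from compound 2 to compound 3 (0.00 log units; within the scatter).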

Compound 3, half-maximal inhibitory concentration: 960 nM
Estimate against measurement, compound 3: 2.0-fold (0.30 log units) above; low and high end bracket the measured number.
By their numbers in this assay, from the lowest: compounds 3, 1 and 2 (each within the scatter of the next).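

In this assay, the exchange of 4-hydroxyphenyl for 3-hydroxy-4-methoxyphenyl on a carbon with a double bond to nitrogen, which adds more to the group than the earlier loss of a single hydroxy, still stays within the scatter (a 2.0-fold lower number from compound 2 to compound 3 (0.30 log units; within the scatter)). Methyl in place of hydrogen on an oxygen on an aromatic ring also stays within the scatter (a 2.0-fold lower number from compound 1 to compound 3 (0.29 log units; within the scatter)), so the three compounds cannot be ordered, and neither removing a hydroxy nor adding this methyl has yet produced a step beyond the scatter at this position. No accompanying measurement offers an explanation for these readings.

As far as these compounds go, it remains open whether an amine or a carboxylic acid on this phenyl group, or a longer chain in place of the methyl on the oxygen, would give a step beyond the scatter. Since all three compounds share the rest of their structure, they also leave open how much that shared core contributes to the numbers in this cell assay.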